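This account rests on a few compounds, and the source may have more. Where it says the series, first, only, none or still open, it means among the compounds named here.

Of the compounds shown here, three sharing one core have been tested so far in a functional assay on A549 cells (Homo sapiens) for inhibition, read by MTT assay, with a stated time of 48 h (on this read-out higher numbers stand for weaker inhibition and lower numbers for stronger inhibition), on these cells. Compound 1 (`N#Cc1ccc(-c2nc3ccccn3c2Sc2ccccc2)cc1`) gives 35200 nM there, compound 2 (`c1ccc(Sc2c(-c3cccs3)nc3ccccn23)cc1`) gives 16900 nM and compound 3 (`Clc1ccc(Sc2c(-c3cccs3)nc3ccccn23)cc1`) gives 69800 nM in the same test. Compound 3 therefore sits level with compound 1 within the usual scatter, and clearly above compound 2, which here means weaker inhibition than compound 2.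

Compound 4 (`Clc1ccc(Sc2c(-c3ccccc3)nc3ccccn23)cc1`) is compound 3 with one change: phenyl in place of thiophen-2-yl on an aromatic carbon. For the measured compounds named here, no pair with exactly this swap has been measured. The closest case touches the same place on the core: thiophen-2-yl in place of 4-cyanophenyl gave a 2.1-fold lower number from compound 1 to compound 2 (0.32 log units; beyond the scatter) and was a modest step. Read backwards, it hints at a somewhat higher number when a six-membered ring returns, although the phenyl of compound 4 carries no cyano group. The other step, chloro in place of hydrogen, gave a 4.1-fold higher number from compound 2 to compound 3 (0.62 log units; beyond the scatter) at a different place, and compound 4 keeps that chloro.

A small upward move in this assay is expected, one that stays within the scatter: the estimated change is a 1.2-fold higher number from compound 3 to compound 4 (0.09 log units; within the scatter) and no more. The estimated value for compound 4 is 85000 nM with an expected range from 30000 nM to 200000 nM on this read-out.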

Compound 4, half-maximal inhibitory concentration: 27700 nM
Compound 4: the middle estimate sits 3.1-fold (0.49 log units) above what was measured, and the stated range ends above it.
By their numbers in this assay, from the lowest: compounds 2, 4, 1 and 3 (each within the scatter of the next, the first and the last beyond it).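

At this aromatic carbon, phenyl in place of thiophen-2-yl gives a 2.5-fold lower number from compound 3 to compound 4 (0.40 log units; beyond the scatter) in this assay, so a plain six-membered carbon ring can give a lower number than thiophen-2-yl when the chloro group is present. For the compounds shown here, the only earlier step at this place, thiophen-2-yl in place of 4-cyanophenyl, also lowered the number, giving a 2.1-fold lower number from compound 1 to compound 2 (0.32 log units; beyond the scatter), which shows that thiophen-2-yl does not lead to the lower number in both pairs: it does in the pair without the chloro group, where the six-membered ring carries a cyano group, and it does not in the pair with the chloro group, where the phenyl is bare. Nothing available here explains why the two steps run in these directions.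

These two pairs differ in both the chloro and the cyano group, so the compounds shown cannot tell which of the two matters, or whether the phenyl step would hold without the chloro group. As far as these compounds go, how an amine or a carboxylic acid on that phenyl, or a longer chain at this carbon, would move the number also remains open.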